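Acetyl to nitro on the indole of the glycosylated triazole series

The source may hold more compounds than are shown below. What is called first, only, known or untested is meant among the compounds shown, and "the series" means these compounds.

Two compounds have numbers in a functional assay on DU-145 cells (Homo sapiens) for cytotoxicity, read by sulforhodamine B assay, with a stated time of 48 h; on this read-out higher numbers stand for weaker inhibition and lower numbers for stronger inhibition. Compound 1 `COc1ccc2c(c1)c(C=O)cn2Cc1cn([C@@H]2O[C@H](COC(C)=O)[C@@H](OC(C)=O)[C@H](OC(C)=O)[C@H]2OC(C)=O)nn1` gives 136000 nM there. Compound 2 `CC(=O)OC[C@H]1O[C@@H](n2cc(Cn3cc(C(C)=O)c4ccccc43)nn2)[C@H](OC(C)=O)[C@@H](OC(C)=O)[C@@H]1OC(C)=O` gives 75200 nM in this assay, the lower of the two numbers, though its gap to compound 1 lies within the scatter, so no order between them is claimed. Compound 3 `CC(=O)OC[C@H]1O[C@@H](n2cc(Cn3cc([N+](=O)[O-])c4ccccc43)nn2)[C@H](OC(C)=O)[C@@H](OC(C)=O)[C@@H]1OC(C)=O` carries the change (nitro in place of acetyl on an aromatic carbon), nitro in place of acetyl on an aromatic carbon. Going by the values given here, no measured pair shows this change, so the step is expected to be small, none beyond the scatter in either direction. The step from compound 2 to compound 3 is expected to be a 1.1-fold higher number from compound 2 to compound 3 (0.03 log units; within the scatter). Compound 3 is thus estimated at 80000 nM in this assay, with a range from 30000 nM to 200000 nM.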

Compound 3, half-maximal inhibitory concentration: 60900 nM
Beside the measured number, compound 3's estimate is 1.3-fold (0.12 log units) above it, and the stated range covers the measured number.
By their numbers in this assay, from the lowest: compounds 3, 2 and 1 (each within the scatter of the next, the first and the last beyond it).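

Nitro in place of acetyl gives the first comparison in the series that differs in one place: in this assay the change gives a 1.2-fold lower number from compound 2 to compound 3 (0.09 log units; within the scatter) and so cannot be told from the scatter. Both groups have the same heavy-atom count, so the pair does not test a larger group at this position. No available evidence bears on this result. As far as these compounds go, whether an amine or a carboxylic acid here would give a number beyond the scatter remains open. From the compounds shown here alone, the same change on the core of compound 1 also remains open.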